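Methyl for Fluoro on the Benzyl Ether of a Dimethyl Oxindole Core

A few compounds are considered here, and "the series" means these few. Any claim that something is new, unique, unknown or untested is made for them only; others in the source may bear on it.

Measured compounds:
compound 1, `O=C1Nc2ccc(OCc3cccc(Cl)c3)cc2C1=O`: 93%
compound 2, `CC(C)=C1C(=O)Nc2ccc(OCCOc3ccccc3)cc21`: "not active" (no number reported)
compound 3, `CC1(C)C(=O)Nc2ccc(OCc3ccc(F)cc3)cc21`: "not active" (no number reported)

Of the compounds shown here, three have been tested in an assay on cells for inhibition of Amine oxidase [flavin-containing] B (Homo sapiens), read by fluorescence, with stated times of 30 min and 15 min, tested at 1 uM; a higher number here means more inhibition at the concentration tested (going by the name of the read-out), a lower number less inhibition. For the measured compounds named here, compound 1, `O=C1Nc2ccc(OCc3cccc(Cl)c3)cc2C1=O`, is the only one with a number: in this assay compound 1 gives 93%. Compound 2, `CC(C)=C1C(=O)Nc2ccc(OCCOc3ccccc3)cc21`, gives "not active" (no number reported) in this assay, and compound 3, `CC1(C)C(=O)Nc2ccc(OCc3ccc(F)cc3)cc21`, likewise gives "not active" (no number reported) in this assay. So compound 3 stands without a number, as one of two compounds reported only as not active, while compound 1 with its quite different core is the sole active one.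

Compound 4, `Cc1ccc(COc2ccc3c(c2)C(C)(C)C(=O)N3)cc1`, keeps the core of compound 3 and changes only the far ring: methyl in place of fluoro on an aromatic carbon. The new group sits para to a large group, exactly where the fluoro sat.

Going by the values given here, no step between measured compounds is available to size this change. Since compound 3 shows no measurable inhibition, a step upward large enough to exceed the scatter of this assay seems unlikely, and a step of no size beyond the scatter is the more probable outcome. Compound 4 is therefore expected to give about 12% in this assay, with a plausible range from 0% to 40%, because compound 3 gives "not active" (no number reported).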

Compound 4, a percentage reported as inhibition, at one concentration (the size of the read-out at that concentration, not a potency): "not active" (no number reported)
Compound 4 has no reported number here, and the estimate cannot be compared.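

In this assay, for the compounds shown here, compound 3 gives "not active" (no number reported) and compound 4 gives "not active" (no number reported) and so no step between them can be read. The compounds shown leave open whether fluoro and methyl at this place differ in inhibition at all. No measured evidence bears on this result.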